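Removing One Methyl from a Fully Methylated Biphenyl Triol

This account rests on a few compounds, and the source may have more. Where it says the series, first, only, none or still open, it means among the compounds named here.

Measured so far:
- Compound 1 `COc1cc(-c2ccccc2)cc(O)c1O`: in a functional assay on SK-OV-3 cells (Homo sapiens) for cytotoxicity, read by sulforhodamine B assay (a higher number here means a weaker inhibitor, a lower number a stronger inhibitor), compound 1 gives > 10000 nM, which is a limit of the assay and not a number.
- Compound 2 `COc1cc(-c2ccccc2)cc(OC)c1OC`: in this assay compound 2 gives > 10000 nM, again a limit rather than a number.

For the measured compounds named here, compound 2 therefore stands at the limit of this assay, and so does the only other compound measured, as the evidence summarises: the limit of > 10000 nM in this assay, at which 2 of the 2 values shown sit. Compound 3 `COc1cc(-c2ccccc2)cc(OC)c1O` differs from compound 2 in one place: hydrogen in place of methyl on an oxygen on an aromatic ring. Going by the values given here, no step between measured compounds is available to show how large an effect this change has. With both measured compounds sitting at the limit, no movement beyond the scatter is expected for the step to compound 3. Compound 3 is therefore expected to remain at or beyond the limit, estimated at 20000 nM with a range from 8000 nM to 50000 nM. Among the compounds with values here, the step from compound 2 to compound 3 that this estimate means is a step that the limit leaves unreadable from compound 2 to compound 3, and it is expected to be no step at all.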

Compound 3, half-maximal inhibitory concentration: > 10000 nM
Compound 3: no number, only a limit (the forecaster's own chance of this, stated with the estimate: 85%); the middle value lies beyond the limit too.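

In this assay compound 3 gives > 10000 nM, which is a limit and not a number. The steps linking compound 3 to compound 1 and compound 2 therefore cannot be read. The compounds shown leave open whether exchanging methoxy for hydroxy changes potency at all: the limit of > 10000 nM in this assay, at which 3 of the 3 values shown sit.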